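The compounds below may be only part of what the source reports. "The series", "measured", "known", "first", "only" and "open" are said of these compounds alone.

In a functional assay on A2780 cells (Homo sapiens) for inhibition, read by sulforhodamine B assay, with a stated time of 72 h (a lower number here means a stronger inhibitor, a higher number a weaker inhibitor), three related amides have been tested so far. Among the measured compounds shown here, compound 2 `O=C(NCc1ccc(S(=O)(=O)N2CCCCC2)cc1)c1cc2cnccc2s1` gives 1600 nM, the only true number among them. Compound 1 `O=C(NCc1ccc(S(=O)(=O)c2ccccc2)cc1)c1cc2ncccc2s1` reads > 10000 nM, which is a limit of the assay and not a number. Compound 3 `O=C(NCc1ccc(S(=O)(=O)c2ccccc2)cc1)c1cc(-c2cccnc2)no1` reads > 10000 nM, which is also a limit. The picture so far is therefore (the limit of > 10000 nM in this assay, at which 2 of the 3 values shown sit). For the measured compounds named here, no two tested compounds differ in just one place, so no measured step can serve as a guide.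

Compound 4 `O=C(NCc1ccc(S(=O)(=O)N2CCCCC2)cc1)c1cc2cccnc2s1` has not yet been measured. It has the same atoms as compound 2, joined differently, and the change is a group of 9 heavy atoms (7 carbon, 1 nitrogen, 1 sulfur; one five-membered aromatic ring with 1 hetero atom, one six-membered aromatic ring with 1 hetero atom) in place of a group of 9 heavy atoms (7 carbon, 1 nitrogen, 1 sulfur; one five-membered aromatic ring with 1 hetero atom, one six-membered aromatic ring with 1 hetero atom), on a carbonyl carbon. The swap happens on a carbonyl carbon, and the counted make-up of the two groups is identical, so the counts alone give no direction. The expectation of a loss rather than a gain rests on thin ground: compound 2 at 1600 nM is the lone number, while the rest of the series sits at the limit of > 10000 nM in this assay, at which 2 of the 3 values shown sit. In this assay, the expected change is a 3.1-fold higher number from compound 2 to compound 4 (0.49 log units; beyond the scatter), a weakening beyond the usual scatter. For compound 4 the estimate is 5000 nM, with an expected range of 1500 nM to 10000 nM.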

Compound 4, half-maximal inhibitory concentration: > 10000 nM
Compound 4: only a limit was reported; the forecaster's own chance of this, stated with the estimate: 40%; at least 2.0-fold (0.30 log units) between middle value and limit.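

In this assay, among the compounds shown here, the new result gives the first measured step between two compounds that differ in one place, and that step is an at least 6.2-fold higher number from compound 2 to compound 4 (0.79 log units; beyond the scatter). The group on the carbonyl carbon keeps the same atoms, the same two aromatic rings and the same counts of hydrogen-bond donors and acceptors, and the rest of the molecule is unchanged, so the way those atoms are joined is all that separates a measured value from a limit of the assay. Compound 2 remains the only compound shown with a true number, so the step gives only a minimum size and no measured ranking among the other compounds: the limit of > 10000 nM in this assay, at which 3 of the 4 values shown sit.

How far compound 4 lies beyond its limit remains open, and so does the full size of the step, and nothing shown explains why this rearrangement of atoms weakens inhibition. It also remains open whether the same rearrangement would have a similar effect with a different group on the sulfonyl, such as a morpholine or a simple dimethylamine, in place of the ones shown here.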